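This account rests on a few compounds, and the source may have more. Where it says the series, first, only, none or still open, it means among the compounds named here.

Going by the values given here, compound 1, `CC(C)[C@@H](Nc1nc(Cl)nc2c1ncn2[C@H]1[C@H](O)[C@H](O)[C@]2(CF)C[C@H]12)C1CC1`, is the one member of this small set with a plain number in an ADME assay on Vero 76 cells (Chlorocebus sabaeus) for cytotoxicity, read by neutral red uptake; on this read-out lower numbers stand for higher toxicity in this test and higher numbers for lower toxicity in this test: in this assay compound 1 gives 33000 nM. Compound 2, `OC[C@@]12C[C@@H]1[C@@H](n1cnc3c(NCc4ccccc4)nc(Cl)nc31)[C@H](O)[C@@H]2O`, is the other measured member, and in this assay compound 2 reaches only a limit, > 100000 nM. So compound 1 stands as the only number shown, while the remaining value sits at the limit of > 100000 nM in this assay, at which 1 of the 2 values shown sits. Among the compounds with values here, no pair of measured compounds differs in just one place, so no measured step is at hand to calibrate the change that leads to compound 3, `CSC[C@@]12C[C@@H]1[C@@H](n1cnc3c(N[C@H](C(C)C)C4CC4)nc(Cl)nc31)[C@H](O)[C@@H]2O`, which has yet to be tested in this assay.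

The change from compound 1 to compound 3 is methylsulfanyl in place of fluoro on a saturated chain carbon bound to a saturated ring carbon. Within the data shown here, with no comparable measured step to lean on, the account expects the move from compound 1 to compound 3 to stay within the usual scatter, a 1.2-fold higher number from compound 1 to compound 3 (0.08 log units; within the scatter), with neither a clear rise nor a clear fall. Compound 3 is therefore estimated at 40000 nM in this assay, within a range from 12000 nM to 130000 nM.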

Compound 3, half-maximal cytotoxic concentration: 32000 nM
Estimate against measurement, compound 3: 1.3-fold (0.10 log units) above; measured number inside the range.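

In this assay, going by these compounds alone, methylsulfanyl in place of fluoro on a saturated chain carbon bound to a saturated ring carbon gives a 1.0-fold lower number from compound 1 to compound 3 (0.01 log units; within the scatter), the first measured step at this position, where the earlier compounds offered none. The exchange brings in two heavy atoms for one, including a sulfur, and one hydrogen-bond acceptor where fluoro has none, yet the read-out shows no change beyond the scatter, so for this pair the cytotoxicity reading does not separate the two groups. Compound 2 still gives no number for comparison, and it differs from compound 1 in more than one place, so its value remains only a limit of the assay: the limit of > 100000 nM in this assay, at which 1 of the 3 values shown sits.

Going by these compounds, with a single step, it remains open whether this flat result extends to other groups at this place, such as a primary amine, a carboxylic acid or a longer thioether chain like ethylsulfanyl. On these data alone, it also remains open whether the same exchange would read alike on the core of compound 2, where any step would have to be measured against a limit rather than a number.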